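The source may report more compounds than this note shows. Statements on the series, on what has been measured and on what is new or still open speak of the compounds shown alone.

Measured so far in an assay on CHO cells for antagonist activity at transient receptor potential cation channel subfamily V member 1 (Homo sapiens), read by FLIPR; a higher number here means a weaker inhibitor, a lower number a stronger inhibitor:
- compound 1 `CC(C(=O)NCc1ccc(C(F)(F)F)cc1N1CCN(C2CCCCC2)CC1)c1ccc(NS(C)(=O)=O)c(F)c1`: 13.8 nM
- compound 2 `CCCCSc1cc(C(F)(F)F)ccc1CNC(=O)C(C)c1ccc(NS(C)(=O)=O)c(F)c1`: 1.9 nM
- compound 3 `CC(C(=O)NCc1ccc(C(F)(F)F)cc1Cl)c1ccc(NS(C)(=O)=O)c(F)c1`: 4 nM

Compound 3 holds the second-lowest number of the three: compound 2 lies a 2.1-fold higher number from compound 2 to compound 3 (0.32 log units; beyond the scatter) away on the stronger side, compound 1 a 3.5-fold lower number from compound 1 to compound 3 (0.54 log units; beyond the scatter) away on the weaker side. The steps among the measured set all turn on the same aromatic carbon of the shared core: a 7.3-fold lower number from compound 1 to compound 2 (0.86 log units; beyond the scatter) and a 3.5-fold lower number from compound 1 to compound 3 (0.54 log units; beyond the scatter) describe what happens when the 4-cyclohexylpiperazin-1-yl group is exchanged for a smaller substituent, and a 2.1-fold higher number from compound 2 to compound 3 (0.32 log units; beyond the scatter) the gap between the two smaller ones.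

Compound 4 `COc1cc(OC)cc(-c2cc(C(F)(F)F)ccc2CNC(=O)C(C)c2ccc(NS(C)(=O)=O)c(F)c2)c1` continues this exchange in the opposite direction: 3,5-dimethoxyphenyl in place of chloro on an aromatic carbon, sitting on an aromatic carbon of a six-membered aromatic ring of carbon only, ortho to a large group, meta to a trifluoromethyl group. Among the compounds with values here, the only bearing steps show that a large substituent at this carbon (compound 1) sits at the weaker end, while butylsulfanyl (compound 2) sits at the stronger end, so the direction for an aromatic replacement is not settled. The expected step is a 1.5-fold higher number from compound 3 to compound 4 (0.18 log units; within the scatter), and the uncertainty around that estimate is wide. Compound 4 is therefore estimated at 6 nM in this assay, within 1.5 nM to 25 nM.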

Compound 4, inhibition constant: 5.8 nM
For compound 4 the middle estimate is 1.0-fold (0.01 log units) above the measured one, within the range that was stated.
By their numbers in this assay, from the lowest: compound 2; then compounds 3 and 4 (each within the scatter of the next); then compound 1.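

In this assay, the exchange of chloro for 3,5-dimethoxyphenyl on this aromatic carbon, meta to a trifluoromethyl group, brings 10 heavy atoms in place of 1, yet a 1.5-fold higher number from compound 3 to compound 4 (0.16 log units; within the scatter) stays within the scatter, so this carbon tolerates an added aromatic ring with no readable change from chloro. A large group here is therefore not tied to the weaker end of the series: compound 1 alone could have suggested that, but a 2.4-fold lower number from compound 1 to compound 4 (0.38 log units; beyond the scatter) separates two large groups by a step beyond the scatter, although the 3,5-dimethoxyphenyl group still does not match butylsulfanyl, with a 3.1-fold higher number from compound 2 to compound 4 (0.48 log units; beyond the scatter) also beyond the scatter. No measurement at hand offers a reason for these gaps.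

Open, from the compounds shown here alone, is what the two methoxy groups contribute at this carbon, a question that an unsubstituted phenyl or a 3-methoxyphenyl group would address. Also open, going by these compounds, is whether the edge of butylsulfanyl belongs to its sulfur or to its chain, which butoxy and methylsulfanyl groups would separate.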